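This account rests on a few compounds, and the source may have more. Where it says the series, first, only, none or still open, it means among the compounds named here.

Compound 3, with the structure `O=C(Nc1cccc(-c2oc3cc(-c4ccc(F)cc4)ccc3c(=O)c2O)c1)c1ccc(C(F)(F)F)cc1`, is one of three compounds that share a common core and differ only in the group at the far end of the amide-linked ring. In a functional assay on HeLa cells (Homo sapiens) for antiproliferative activity, read by CCK-8 assay, with a stated time of 72 h (on this read-out higher numbers stand for weaker inhibition and lower numbers for stronger inhibition), compound 3 gives 17400 nM. This is the highest number of the three. Compound 1, with the structure `O=C(Nc1cccc(-c2oc3cc(-c4ccc(F)cc4)ccc3c(=O)c2O)c1)c1ccc(F)cc1`, gives 5350 nM in this assay, and compound 2, with the structure `COc1ccc(C(=O)Nc2cccc(-c3oc4cc(-c5ccc(F)cc5)ccc4c(=O)c3O)c2)cc1`, gives 4820 nM. The steps from these two to compound 3 are both beyond the scatter: a 3.3-fold higher number from compound 1 to compound 3 (0.51 log units; beyond the scatter), and a 3.6-fold higher number from compound 2 to compound 3 (0.56 log units; beyond the scatter). So compound 3 is the weakest of the measured set, while compounds 1 and 2 sit close together, as shown by a 1.1-fold lower number from compound 1 to compound 2 (0.05 log units; within the scatter).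

Compound 4, with the structure `CCc1ccc(C(=O)Nc2cccc(-c3oc4cc(-c5ccc(F)cc5)ccc4c(=O)c3O)c2)cc1`, has not been measured. It differs from compound 3 in one place: ethyl in place of trifluoromethyl on an aromatic carbon. Among the compounds with values here, two measured steps bear on this change, since both replace the trifluoromethyl group of compound 3 with a different small group at the same place, and both gave clearly lower numbers. An ethyl group has not been tried, so the expectation rests on those two steps alone. On that basis a lower number is expected for compound 4, roughly a 2.9-fold lower number from compound 3 to compound 4 (0.46 log units; beyond the scatter), landing near the range of compounds 1 and 2. The estimate for compound 4 in this assay is 6000 nM, with a likely range from 3000 nM to 15000 nM.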

Compound 4, half-maximal inhibitory concentration: 21000 nM
Compound 4: the middle estimate sits 3.5-fold (0.54 log units) below what was measured, and the stated range ends below it.
By their numbers in this assay, from the lowest: compounds 2 and 1 (each within the scatter of the next); then compounds 3 and 4 (each within the scatter of the next).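

In this assay, swapping trifluoromethyl for ethyl at this place on the ring leaves the reading unchanged within the usual scatter, with a 1.2-fold higher number from compound 3 to compound 4 (0.08 log units; within the scatter) on this step. The weak result of compound 3 is therefore not tied to trifluoromethyl alone, since ethyl, a group with no fluorine at all, lands in the same range; the four compounds now fall into two pairs, fluoro and methoxy on the stronger side and trifluoromethyl and ethyl on the weaker side, and the gap between the pairs is clear in both a 4.4-fold higher number from compound 2 to compound 4 (0.64 log units; beyond the scatter) and a 3.9-fold higher number from compound 1 to compound 4 (0.59 log units; beyond the scatter) as the ethyl compound is set against the two stronger ones. Nothing available here accounts for this split into two pairs.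

The compounds shown leave open whether a longer chain such as propyl would stay with the weaker pair, and whether an amine or a carboxylic acid at this place would join the stronger pair or the weaker one. They also leave open whether a hydroxyl or a chloro group would fit this two-pair picture at all.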